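The source may report more compounds than this note shows. Statements on the series, on what has been measured and on what is new or still open speak of the compounds shown alone.

Of the compounds shown here, two of a shared core have been measured. Compound 1, with the structure `CC1=C(C)C(=O)c2nn(Cc3ccccc3)nc2C1=O`, gives 0.8 ug/mL in a functional assay on HeLa cells (Homo sapiens) for inhibition, read by colorimetric assay, with a stated time of 72 h; on this read-out lower numbers stand for an effect already at smaller amounts and higher numbers for an effect only at larger amounts of compound. Compound 2, with the structure `CC1=CC(=O)c2nn(C)nc2C1=O`, gives 0.3 ug/mL in this assay, which is the lower of the two numbers; its distance from compound 1 is beyond the usual scatter, so compound 2 shows its effect at smaller amounts than compound 1.

The next compound, compound 3, has the structure `CC1=C(C)C(=O)c2nn(C)nc2C1=O`. It is built from compound 2 by a single change: methyl in place of hydrogen on a double-bonded ring carbon, a methyl in place of hydrogen on a double-bonded ring carbon. Among the measured compounds shown here, no pair of measured compounds shows exactly this change, so its effect cannot be read off directly. Compound 1 also carries two methyl groups on that ring but differs elsewhere as well, so it offers only a loose hint.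

For compound 3 the step of a 1.7-fold higher number from compound 2 to compound 3 (0.22 log units; within the scatter) is expected to be small, toward a somewhat higher number, and probably within the scatter. Compound 3 is therefore estimated at 0.5 ug/mL, in the range 0.2 ug/mL to 1.2 ug/mL.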

Compound 3, concentration for half-maximal effect: 0.5 ug/mL
Beside the measured number, compound 3's estimate shows no gap at the digits printed; the measured number falls inside the stated range.
By their numbers in this assay, from the lowest: compounds 2, 3 and 1 (each within the scatter of the next, the first and the last beyond it).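

In this assay, methyl in place of hydrogen on a double-bonded ring carbon gives a 1.7-fold higher number from compound 2 to compound 3 (0.22 log units; within the scatter) and so leaves compound 2 and compound 3 indistinguishable: this ring carbon, the one next to the ring atom that bears a methyl group, can carry the extra methyl with no effect that stands out from the usual scatter. The second single step, hydrogen in place of phenyl on a saturated chain carbon bound to an aromatic nitrogen, gives a 1.6-fold lower number from compound 1 to compound 3 (0.20 log units; within the scatter) and so also stays within the scatter, which means that compound 1 and compound 3 cannot be told apart in this assay either. No measurement shown here offers an explanation for either of these steps.

The compounds shown hold only hydrogen and methyl on this double-bonded ring carbon, so what an ethyl group, a methoxy group or an amine would do there remains open. Equally open, going by these compounds, is what a carboxylic acid in place of the phenyl would do on the saturated chain carbon bound to an aromatic nitrogen.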